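The source may report more compounds than this note shows. Statements on the series, on what has been measured and on what is new or still open speak of the compounds shown alone.

Compound 1 `COc1ccc2[nH]c(-c3nc(-c4ccccc4)no3)cc2c1` and compound 2 `Clc1ccc2[nH]c(-c3nc(-c4ccccc4)no3)cc2c1` share one core and differ only at its edge. In a functional assay on COLO 320 cells (Homo sapiens) for antiproliferative activity, read by WST assay, with a stated time of 72 h (a lower number here means a stronger inhibitor, a higher number a weaker inhibitor), compound 1 gives 18700 nM, and compound 2 gives 16500 nM. The step of a 1.1-fold lower number from compound 1 to compound 2 (0.05 log units; within the scatter) shows how little that swap mattered, so compound 2 stands alongside compound 1 rather than apart from it. Compound 3 `Clc1ccc(-c2noc(-c3cc4cc(Cl)ccc4[nH]3)n2)cc1` differs from compound 2 by chloro in place of hydrogen on an aromatic carbon. Going by the values given here, no measured step touches that ring, and the one step known, a 1.1-fold lower number from compound 1 to compound 2 (0.05 log units; within the scatter), was small. A step of about a 1.4-fold lower number from compound 2 to compound 3 (0.14 log units; within the scatter) is therefore expected, hardly beyond the scatter. Compound 3 is estimated at 12000 nM, within a range from 4000 nM to 35000 nM.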

Compound 3, half-maximal inhibitory concentration: 25000 nM
Beside the measured number, compound 3's estimate is 2.1-fold (0.32 log units) below it; measured number inside the range.
By their numbers in this assay, from the lowest: compounds 2, 1 and 3 (each within the scatter of the next).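

Going by these compounds alone, the earlier compounds left this phenyl ring untouched, so this is the first look at it. In this assay the change from phenyl to 4-chlorophenyl, para to a large group, gives a 1.5-fold higher number from compound 2 to compound 3 (0.18 log units; within the scatter) and so cannot be told apart from no change at all. Nothing measured here speaks to the reason for this result. Still open, from the compounds shown here alone, is whether a different kind of group at this position, such as an amine or a carboxylic acid, would move the number beyond the scatter.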